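The source may report more compounds than this note shows. Statements on the series, on what has been measured and on what is new or still open speak of the compounds shown alone.

In a functional assay on HeLa cells (Homo sapiens) for cytotoxicity, read by MTT assay (on this read-out higher numbers stand for weaker inhibition and lower numbers for stronger inhibition), compound 1 `CC(C)=CC[C@@H](OC(=O)c1ccoc1)C1=CC(=O)c2c(O)ccc(O)c2C1=O` reaches only the limit of the assay, > 100000 nM. Compound 2 `CC(C)=CC[C@@H](OC(=O)C1CCOC1)C1=CC(=O)c2c(O)ccc(O)c2C1=O` gives 73500 nM in this assay. Compound 3 `CC(C)=CC[C@@H](OC(=O)C1CCCCO1)C1=CC(=O)c2c(O)ccc(O)c2C1=O` also reaches only a limit, > 100000 nM, so its standing among the three is known as a bound alone. The step of an at least 1.3-fold lower number from compound 1 to compound 2 (0.13 log units; that floor lies within the scatter) and the step of an at least 1.3-fold higher number from compound 2 to compound 3 (0.13 log units; that floor lies within the scatter) stay within the scatter, while the step that the two limits leave unreadable from compound 1 to compound 3 cannot be read because of the limit of > 100000 nM in this assay, at which 2 of the 3 values shown sit. Compound 4 `CCCC(CC(=O)O[C@H](CC=C(C)C)C1=CC(=O)c2c(O)ccc(O)c2C1=O)OC(C)=O` is not yet measured; it differs from compound 3 in that (2-acetoxypentyl in place of oxan-2-yl on a carbonyl carbon). Every measured step here is small or unreadable, so no step beyond the scatter is expected. Compound 4 is therefore expected to give 90000 nM, between 40000 nM and 200000 nM. The step of an at least 1.1-fold lower number from compound 3 to compound 4 (0.04 log units; that floor lies within the scatter) is what this estimate means.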

Compound 4, half-maximal inhibitory concentration: 51200 nM
For compound 4 the middle estimate is 1.8-fold (0.24 log units) above the measured one; low and high end bracket the measured number.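

Compound 4 shows that an open chain, 2-acetoxypentyl, can sit on this carbonyl carbon in place of a ring and still give a measured number in this assay rather than a limit. The steps are an at least 1.9-fold lower number from compound 3 to compound 4 (0.29 log units; that floor lies within the scatter), an at least 1.9-fold lower number from compound 1 to compound 4 (0.29 log units; that floor lies within the scatter) and a 1.4-fold lower number from compound 2 to compound 4 (0.16 log units; within the scatter), and all three lie within the scatter, so a ring here is not shown to be needed. The first two are only floors, and their full size cannot be read because one end of each is a limit: the limit of > 100000 nM in this assay, at which 2 of the 4 values shown sit.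

The compounds shown leave open whether the acetoxy group or the open chain itself accounts for the reading of compound 4. They also leave open what an amine or a carboxylic acid on this carbonyl carbon would give.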